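Compound 4: a large new group on the shared core

The compounds below may be only part of what the source reports. "The series", "measured", "known", "first", "only" and "open" are said of these compounds alone.

Compound 1 `CCCCC(=O)C1CCN(C(=O)c2cc3sccc3n2Cc2ccc(OC)cc2)CC1` in an ADME assay on HEK-293T cells (Homo sapiens) for cytotoxicity, read by luminescence, with a stated time of 24 h (a higher number here means that more compound is tolerated, a lower number that less compound is tolerated), gives 38900 nM
Compound 2 `CCCNC(=O)C1CCN(C(=O)c2cc3sccc3n2Cc2ccc(OC)cc2)CC1` gives 18800 nM
Compound 3 `CCCNC(=O)C1CCN(C(=O)c2cc3sc(-c4ccccc4)cc3n2Cc2ccc(OC)cc2)CC1` gives > 100000 nM, which is a limit of the assay and not a number

Among the measured compounds shown here, only two compounds have true numbers, and the lower of them belongs to compound 2. Propylamino in place of butyl on a carbonyl carbon gave a 2.1-fold lower number from compound 1 to compound 2 (0.32 log units; beyond the scatter), so less of compound 2 is tolerated than of compound 1.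

Compound 4 `CCCNC(=O)C1CCN(C(=O)c2c(CNC(C)c3ccccc3)c3sccc3n2Cc2ccc(OC)cc2)CC1` keeps everything in compound 2 but carries ((1-phenylethyl)amino)methyl in place of hydrogen on an aromatic carbon. The best guide is the other change made on an aromatic carbon, phenyl in place of hydrogen, which gave an at least 5.3-fold higher number from compound 2 to compound 3 (0.72 log units; beyond the scatter). That change added a different group at a different carbon, and its full size is hidden by the limit reached by compound 3. The butyl step concerns another part of the molecule and says little here. A rise in this assay is therefore expected, though a much smaller one. The expected step is a 1.6-fold higher number from compound 2 to compound 4 (0.20 log units; within the scatter), small and upward, with no clear move beyond the scatter. For compound 4 the estimated value is 30000 nM, with an expected range from 9000 nM to 100000 nM.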

Compound 4, half-maximal cytotoxic concentration: 57500 nM
Estimate against measurement, compound 4: 1.9-fold (0.28 log units) below; low and high end bracket the measured number.
By their numbers in this assay, from the lowest: compound 2; then compounds 1 and 4 (each within the scatter of the next). At a limit, above all of these: compound 3.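

In this assay, ((1-phenylethyl)amino)methyl in place of hydrogen gives a 3.1-fold higher number from compound 2 to compound 4 (0.49 log units; beyond the scatter), so this carbon, two ring bonds from the ring nitrogen, now has a readable step of its own. Among the compounds shown here, until now the only change on an aromatic carbon was phenyl at a different carbon, and its result ended in a limit, whereas this larger group, with one six-membered aromatic ring and a nitrogen, gives a true number that rises beyond the scatter. Compound 3 gives > 100000 nM, which is a limit and not a number, so the phenyl step cannot be sized against this new step: the limit of > 100000 nM in this assay, at which 1 of the 4 values shown sits.

The compounds shown leave open which part of the new group goes with the rise, and an aminomethyl group alone or a benzyl group without the nitrogen on this same carbon would help to separate those parts. Also open, on these data alone, is whether the same group would move the number in the same direction on a molecule with butyl in place of propylamino.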